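The source may hold more compounds than are shown below. What is called first, only, known or untested is meant among the compounds shown, and "the series" means these compounds.

Measured compounds in a functional assay on DU-145 cells (Homo sapiens) for inhibition, read by trypan blue exclusion, with a stated time of 96 h; on this read-out lower numbers stand for stronger inhibition of growth and higher numbers for weaker inhibition of growth:

compound 1 `Cc1ccc(CS/C(=C/c2cc(C)ccc2C)C(=O)c2ccc(Cl)cc2)cc1`: 10000 nM
compound 2 `Cc1ccc(CS/C(=C/c2c[nH]c3ccc(Br)cc23)C(=O)c2ccc(Cl)cc2)cc1`: 1000 nM
compound 3 `Cc1ccc(CS(=O)(=O)/C(=C/c2c[nH]c3ccc(Br)cc23)C(=O)c2ccc(Cl)cc2)cc1`: 10000 nM

Compound 1 and compound 2 share one core; compound 3 and the unmeasured compound 4 `Cc1ccc(CS(=O)(=O)/C(=C/c2cc(C)ccc2C)C(=O)c2ccc(Cl)cc2)cc1` share another. Within the data shown here, how the core of compound 3 differs from that of compound 2 is not broken down here; their values show only that compound 3 gives the higher number in this assay, while compound 3 and compound 1 are level at the digits given, within the scatter.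

Within the first core the change 2,5-dimethylphenyl in place of 5-bromo-1H-indol-3-yl on a double-bonded chain carbon bound to a double-bonded chain carbon gave a 10-fold higher number from compound 2 to compound 1 (1.00 log units; beyond the scatter). The same change, (2,5-dimethylphenyl in place of 5-bromo-1H-indol-3-yl on a double-bonded chain carbon bound to a double-bonded chain carbon), is now made within the second core.

Among the measured compounds shown here, from compound 3 to compound 4 a smaller step is expected, a 2.0-fold higher number from compound 3 to compound 4 (0.30 log units; within the scatter), because compound 3 already stands at 10000 nM, the highest number among the three measured compounds, and no measured compound shows where a weaker inhibitor would be read. Compound 4 is therefore expected near 20000 nM in this assay. The estimated range for compound 4 runs from 8000 nM to 100000 nM, with a real chance that only a limit is reported.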

Compound 4, concentration for 50% growth inhibition: 1000 nM
The estimate for compound 4 lay 20-fold (1.30 log units) above the measured number; measured number below the stated range.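

In this assay, 2,5-dimethylphenyl in place of 5-bromo-1H-indol-3-yl on a double-bonded chain carbon bound to a double-bonded chain carbon gave a 10-fold lower number from compound 3 to compound 4 (1.00 log units; beyond the scatter), and the change does not carry from one core to the other, since its direction reverses: the same change on two cores in this assay, a 10-fold higher number (1.00 log units; beyond the scatter) from compound 2 to compound 1 and a 10-fold lower number (1.00 log units; beyond the scatter) from compound 3 to compound 4, 100-fold (2.00 log units) apart, beyond the scatter of two such steps

For these four compounds, then, the step measured on one core gives no usable estimate of the step on the other. Among these compounds, with only one pair on each core, the result does not show which difference between the cores goes with the reversal, nor whether it would recur for any other exchange of groups.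

Still open, on these data alone, is how other groups at this place would behave on the two cores, for example a phenyl carrying an amine or a carboxylic acid. Also open, as far as these compounds go, is whether an indol-3-yl with chlorine in place of the bromine would follow compound 2 and compound 3 on their respective cores.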